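Aryl exchange at the carbamate oxygen of compound 3

This account rests on a few compounds, and the source may have more. Where it says the series, first, only, none or still open, it means among the compounds named here.

Compound 3 `CC(C)c1cccc(C(C)C)c1OS(=O)(=O)NC(=O)Oc1cccnc1` gives in an assay on liver for inhibition of sterol O-acyltransferase 1 (Rattus norvegicus), using microsomes (a higher number here means a weaker inhibitor, a lower number a stronger inhibitor), only the assay limit > 50000 nM. Compound 1 `CCC(C)N(C(=O)NS(=O)(=O)Oc1c(C(C)C)cccc1C(C)C)C(C)CC` gives 12000 nM in this assay, and compound 2 `CC(C)c1cccc(C(C)C)c1OS(=O)(=O)NC(=O)O[C@@H]1C[C@H](C)CCC1C(C)C` gives 21000 nM; the steps of an at least 4.1-fold higher number from compound 1 to compound 3 (0.61 log units; beyond the scatter) and an at least 2.3-fold higher number from compound 2 to compound 3 (0.37 log units; beyond the scatter) both run upward, so compound 3 stands at the weak end of the three measured compounds, and its number is open-ended because of the limit of > 50000 nM in this assay, at which 1 of the 3 values shown sits. Compound 4 `CC(C)c1cccc(C(C)C)c1OS(=O)(=O)NC(=O)Oc1ccc(F)cc1F` differs from compound 3 by 2,4-difluorophenyl in place of pyridin-3-yl on an oxygen next to a carbonyl group. No measured step touches this exchange of one aromatic group for another on the oxygen; the two steps shown only place the (pyridin-3-yl)oxy compound 3 at or past the limit. For compound 4 a step of an at least 1.1-fold lower number from compound 3 to compound 4 (0.04 log units; that floor lies within the scatter) is therefore expected, with no direction that clearly exceeds the scatter. Compound 4 is estimated at 45000 nM in this assay, within 15000 nM to 150000 nM.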

Compound 4, half-maximal inhibitory concentration: > 50000 nM
Compound 4 gave a limit, no number (the forecaster's own chance of this, stated with the estimate: 45%); middle value at least 1.1-fold (0.04 log units) away from the limit.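

Compound 4 gives only a limit in this assay, > 50000 nM, so the step from compound 3 cannot be read: the limit of > 50000 nM in this assay, at which 2 of the 4 values shown sit.

With a ring of carbon only on the oxygen, the steps of an at least 2.3-fold higher number from compound 2 to compound 4 (0.37 log units; beyond the scatter) and an at least 4.1-fold higher number from compound 1 to compound 4 (0.61 log units; beyond the scatter) match those of compound 3, so a ring nitrogen is not required for the weak result in these two aromatic compounds. Still open, on these data alone, is how far compound 3 and compound 4 lie beyond the limit, and whether a benzyl group on this oxygen, or a phenyl ring carrying a carboxylic acid, would give a readable number.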